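This account rests on a few compounds, and the source may have more. Where it says the series, first, only, none or still open, it means among the compounds named here.

Values measured so far in an ADME assay on MDBK cells (Bos taurus) for cytotoxicity, read by MTT assay, with a stated time of 96 h; a lower number here means that less compound is tolerated, a higher number that more compound is tolerated
compound 1 `CC[C@H]1CC[C@H](c2ccc(NC(=S)Nc3cccc(C(F)(F)F)c3)cc2)CC1` gives 9000 nM 
compound 2 `Fc1ccc(NC(=S)Nc2cccc(C(F)(F)F)c2)cc1Cl` gives 11000 nM 
compound 3 `O=C(NC(=S)Nc1cccc(C(F)(F)F)c1)[C@H]1C[C@@H]2CC[C@H]1C2` gives 10000 nM 

Compound 1 stands level with the other two, as all three values lie within the usual scatter of repeated measurements. Compound 4 `CCOC(=O)c1ccc(NC(=S)Nc2cccc(C(F)(F)F)c2)cc1` has not yet been measured. It differs from compound 1 by ethoxycarbonyl in place of 4-ethylcyclohexyl on an aromatic carbon, para to a large group. Among the measured compounds shown here, no measured pair differs in only one place, so nothing shows directly how large such a step is. Still, compound 2 (11000 nM) and compound 3 (10000 nM) remain within the scatter of compound 1 (9000 nM) even though they carry quite different groups on the shared core. On that limited evidence, no step beyond the scatter is expected in this assay for this change. The estimated step is a 1.1-fold higher number from compound 1 to compound 4 (0.05 log units; within the scatter) and it would be too small to read as a real difference. The expected value for compound 4 is 10000 nM with an estimated range from 4000 nM to 30000 nM for a single measurement.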

Compound 4, half-maximal cytotoxic concentration: 64000 nM
The estimate for compound 4 lay 6.4-fold (0.81 log units) below the measured number; the whole stated range lies below it.
By their numbers in this assay, from the lowest: compounds 1, 3 and 2 (each within the scatter of the next); then compound 4.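

In this assay, ethoxycarbonyl in place of 4-ethylcyclohexyl on an aromatic carbon, para to a large group, gives a 7.1-fold higher number from compound 1 to compound 4 (0.85 log units; beyond the scatter). This is the only step shown between compounds that differ in one place, and it establishes that the group at this position can move the result beyond the scatter, which the closely grouped earlier values could not show. No measurement at hand indicates why the number rises with this change.

The compounds shown leave open which part of the change matters, as the carbon-only ring leaves and hydrogen-bond acceptors enter in the same step. As far as these compounds go, it also remains open how the number would respond to a carboxylic acid or an amine at this position on the shared core.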